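A few compounds are considered here, and "the series" means these few. Any claim that something is new, unique, unknown or untested is made for them only; others in the source may bear on it.

Measured compounds: compound 1 `COc1ccc(C(=O)NC[C@H]2c3[nH]c4ccccc4c3C[C@H]3[C@H]4c5[nH]c6ccccc6c5C[C@@H]([C@H](C#N)N23)N4C)cc1`, which in a functional assay on HCT-116 cells (Homo sapiens) for cytotoxicity, read by MTT assay, with a stated time of 72 h (on this read-out higher numbers stand for weaker inhibition and lower numbers for stronger inhibition), gives 430 nM; compound 2 `CN1[C@@H]2c3[nH]c4ccccc4c3C[C@H]1[C@H](C#N)N1[C@@H](CNC(=O)c3ccc4ccccc4n3)c3[nH]c4ccccc4c3C[C@@H]21`, which in this assay gives 240 nM.

Going by the values given here, compound 2 and compound 1 lie within the scatter of each other in this assay; the one step between them is a 1.8-fold lower number from compound 1 to compound 2 (0.25 log units; within the scatter). Compound 3 `COc1ccc(/C=C/C(=O)NC[C@H]2c3[nH]c4ccccc4c3C[C@H]3[C@H]4c5[nH]c6ccccc6c5C[C@@H]([C@H](C#N)N23)N4C)cc1` is not yet measured. It differs from compound 2 by 2-(4-methoxyphenyl)ethenyl in place of quinolin-2-yl on a carbonyl carbon. Among the compounds with values here, the only step that bears on this change is a 1.8-fold lower number from compound 1 to compound 2 (0.25 log units; within the scatter), an exchange between the same two aryl groups that stays within the scatter. Compound 3 carries the 4-methoxyphenyl of compound 1 with the ethenyl in between, so for compound 3 the expected step is a 1.5-fold higher number from compound 2 to compound 3 (0.16 log units; within the scatter), none beyond the scatter. Compound 3 is estimated at 350 nM, with a range of 150 nM to 900 nM.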

Compound 3, half-maximal inhibitory concentration: 5060 nM
Beside the measured number, compound 3's estimate is 14-fold (1.16 log units) below it; measured number outside the range, above it.
By their numbers in this assay, from the lowest: compounds 2 and 1 (each within the scatter of the next); then compound 3.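

In this assay the group on the carbonyl carbon is not freely exchangeable: 2-(4-methoxyphenyl)ethenyl gives a 21-fold higher number from compound 2 to compound 3 (1.32 log units; beyond the scatter) and a 12-fold higher number from compound 1 to compound 3 (1.07 log units; beyond the scatter). Compound 3 keeps the 4-methoxyphenyl of compound 1, so the large step goes with the added ethenyl. No supporting measurement explains this step.

Still open, as far as these compounds go, is whether the step belongs to the double bond or to the longer chain, which 2-(4-methoxyphenyl)ethyl would separate. Also open, from the compounds shown here alone, is whether 2-(quinolin-2-yl)ethenyl would show the same large step.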